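A few compounds are considered here, and "the series" means these few. Any claim that something is new, unique, unknown or untested is made for them only; others in the source may bear on it.

Compound 1 `CCCc1n[nH]c2c(=O)n(NC(=O)c3ccncc3)c(-c3cccc(OC)c3)nc12`: 9.13%
Compound 2 `O=C(Nn1c(-c2cccc([N+](=O)[O-])c2)nc2c(-c3ccc(Cl)cc3)n[nH]c2c1=O)c1cccnc1`: 31%

In a functional assay on DU-145 cells (Homo sapiens) for cytotoxicity, read by sulforhodamine B assay, with a stated time of 2 days, tested at 100 uM (a lower number here means less inhibition, a higher number more inhibition at the concentration tested (going by the name of the read-out)), compound 1 gives 9.13%, the lower of the two numbers recorded; compound 2 gives 31%, a higher number that lies beyond the usual scatter. Compound 3 `COc1cccc(-c2nc3c(-c4ccc(Cl)cc4)n[nH]c3c(=O)n2NC(=O)c2ccncc2)c1` has not been measured in this assay. It differs from compound 1 in one place: 4-chlorophenyl in place of propyl on an aromatic carbon. Within the data shown here, compound 2 carries the same 4-chlorophenyl group but differs elsewhere as well, so no direct step for this change is available. A modest rise in inhibition is expected for compound 3, a number 10.9 percentage points higher from compound 1 to compound 3 (beyond the scatter), though it may remain within the scatter. Compound 3 is estimated at 20%, within 5% to 36%.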

Compound 3, a percentage reported as inhibition, at one concentration (the size of the read-out at that concentration, not a potency): 54.4%
The estimate for compound 3 lay 34.4 percentage points below the measured number; the whole stated range lies below it.
By their numbers in this assay, from the lowest: compound 1; then compound 2; then compound 3.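

In this assay, among these compounds, the exchange of propyl for 4-chlorophenyl on the aromatic carbon of the five-membered ring gives a number 45.3 percentage points higher from compound 1 to compound 3 (beyond the scatter) and offers the first direct reading of this position. The step shows that inhibition at this concentration depends strongly on the group held at this carbon when the rest of the molecule stays the same. Nothing available accounts for the rise. On these data alone, how a plain phenyl, a longer chain or an amine at this carbon would compare stays open, as does whether the chlorine contributes to the step.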